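Dimethylamino for Methoxy in a Series Without Readable Potency

A few compounds are considered here, and "the series" means these few. Any claim that something is new, unique, unknown or untested is made for them only; others in the source may bear on it.

Compound 1 `COc1ccc(-n2c(SCC(=O)c3ccccc3)nnc2-c2cc(OC)c(OC)c(OC)c2)cc1` reaches only a limit in a functional assay on HCT-116 cells (Homo sapiens) for inhibition, read by MTT assay, with a stated time of 48 h (on this read-out higher numbers stand for weaker inhibition and lower numbers for stronger inhibition), namely > 60000 nM.
Compound 2 `COc1ccc(-n2c(SCC(=O)c3ccc(F)cc3)nnc2-c2cc(OC)c(OC)c(OC)c2)cc1` likewise reaches only a limit, > 60000 nM.
Compound 3 `COc1ccc(-n2c(SCC(=O)c3ccc4ccccc4c3)nnc2-c2cc(OC)c(OC)c(OC)c2)cc1` also reaches only a limit, > 60000 nM.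

Compound 3 thus stands at the limit of this assay, where every value shown sits (the limit of > 60000 nM in this assay, at which 3 of the 3 values shown sit). The steps a step that the two limits leave unreadable from compound 1 to compound 2, a step that the two limits leave unreadable from compound 1 to compound 3 and a step that the two limits leave unreadable from compound 2 to compound 3 are all unreadable, with both ends of each at that limit. Compound 4 `COc1cc(-c2nnc(SCC(=O)c3ccc4ccccc4c3)n2-c2ccc(N(C)C)cc2)cc(OC)c1OC` differs from compound 3 by dimethylamino in place of methoxy on an aromatic carbon. No measured step bears on this change, and nothing shown gives a readable size for any step. Compound 4 is therefore expected to return a limit again, the expected step of a number no higher from compound 3 to compound 4 (the limit leaves the size open) meaning nothing beyond the scatter. The estimate for compound 4 is 60000 nM, in the range 20000 nM to 150000 nM.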

Compound 4, half-maximal inhibitory concentration: 54500 nM
Compound 4: the middle estimate sits 1.1-fold (0.04 log units) above what was measured; the range from low to high includes it.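

With dimethylamino at this place, compound 4 is the only compound shown in this assay that gives a number rather than a limit: the limit of > 60000 nM in this assay, at which 3 of the 4 values shown sit.

Within the data shown here, the change from 4-methoxyphenyl to 4-(dimethylamino)phenyl thus gives the first step with one readable end, an at least 1.1-fold lower number from compound 3 to compound 4 (0.04 log units; that floor lies within the scatter). How far the step reaches past that floor cannot be read, as compound 3 has only a limit.

From the compounds shown here alone, whether dimethylamino also gives a number with the phenyl of compound 1 or the 4-fluorophenyl of compound 2 stays open. So does the outcome of a primary amine or diethylamino at this place.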